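The source may report more compounds than this note shows. Statements on the series, on what has been measured and on what is new or still open speak of the compounds shown alone.

Measured in an assay for inhibition of Tryptophan 2,3-dioxygenase (Homo sapiens), with stated times of 10 min and 60 min; a higher number here means a weaker inhibitor, a lower number a stronger inhibitor:
compound 1 `O=[N+]([O-])c1cccc(CNc2cc(Br)cc3[nH]ncc23)c1`: 1600 nM
compound 2 `O=[N+]([O-])c1cccc(CNc2cc(C(F)(F)F)cc3[nH]ncc23)c1`: 5170 nM
compound 3 `FC(F)(F)c1cc(NCc2cccc3sccc23)c2cn[nH]c2c1`: > 100000 nM

The entry for compound 3 is a limit of the assay and not a number, as the line the limit of > 100000 nM in this assay, at which 1 of the 3 values shown sits, records. Among the two real numbers, compound 2 holds the higher one, and its nearest neighbour is compound 1; the single measured step, a 3.2-fold higher number from compound 1 to compound 2 (0.51 log units; beyond the scatter), is the only change on the shared core with a known outcome, and it concerns the group on the core, not the aryl part that carries the nitro group.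

Compound 4 `O=C(O)c1cccc(CNc2cc(C(F)(F)F)cc3[nH]ncc23)c1` differs from compound 2 by carboxy in place of nitro on an aromatic carbon. Going by the values given here, no measured step touches this part of the molecule, so the size of the coming step cannot be read from the data; the only hint is that compound 3, with a different aryl part, reaches only the limit. The step is expected to be a 3.9-fold higher number from compound 2 to compound 4 (0.59 log units; beyond the scatter), a loss with a wide uncertainty. Compound 4 is therefore estimated at 20000 nM, between 3000 nM and 100000 nM.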

Compound 4, half-maximal inhibitory concentration: 1690 nM
Estimate against measurement, compound 4: 12-fold (1.07 log units) above, and the stated range ends above it.
By their numbers in this assay, from the lowest: compounds 1 and 4 (each within the scatter of the next); then compound 2. At a limit, above all of these: compound 3.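

In this assay, going by these compounds alone, this is the first measured change on the aryl part rather than on the group at the other end of the core: a 3.1-fold lower number from compound 2 to compound 4 (0.49 log units; beyond the scatter). The position therefore accepts more than nitro, and on this core carboxy, which brings a hydrogen-bond donor that nitro lacks, gives the stronger inhibitor of the pair. Nothing measured here on these compounds accounts for the size or direction of this step.

The entry for compound 3, > 100000 nM, is a limit of the assay and not a number, so it gives no size for a change of the aryl part. Open, from the compounds shown here alone, is whether an amide or a nitrile in place of carboxy, or carboxy paired with bromo in place of trifluoromethyl, would lower the number further.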